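Methoxy on the benzoyl ring of a triazole thioether

A few compounds are considered here, and "the series" means these few. Any claim that something is new, unique, unknown or untested is made for them only; others in the source may bear on it.

Measured compounds:
compound 1, `COc1cc(-c2nnc(SCc3ccccc3)n2-c2ccc(N(C)C)cc2)cc(OC)c1OC`, > 60000 nM
compound 2, `COc1ccc(CSc2nnc(-c3cc(OC)c(OC)c(OC)c3)n2-c2ccc(N(C)C)cc2)cc1`, > 60000 nM
compound 3, `COc1cc(-c2nnc(SCC(=O)c3ccccc3)n2-c2ccc(N(C)C)cc2)cc(OC)c1OC`, 18900 nM

Compound 1 was tested in a functional assay on HepG2 cells (Homo sapiens) for inhibition, read by MTT assay, with a stated time of 48 h; on this read-out lower numbers stand for stronger inhibition and higher numbers for weaker inhibition; its value of > 60000 nM is a limit of the assay and not a number. Compound 2 likewise returns only a limit, > 60000 nM. Within the data shown here, compound 3, by contrast, gives a number, 18900 nM, and is the only compound of the three to do so.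

Compound 1 and compound 2 differ by methoxy in place of hydrogen on an aromatic carbon. The size of this step is not readable, a step that the two limits leave unreadable from compound 1 to compound 2, because the limit of > 60000 nM in this assay, at which 2 of the 3 values shown sit, hides whatever difference there may be. The change from compound 1 to compound 3 is benzoyl in place of phenyl on a saturated chain carbon bound to a sulfur; here the step is clear, an at least 3.1-fold lower number from compound 1 to compound 3 (0.50 log units; beyond the scatter), and the move from compound 2 to compound 3 is of the same kind, an at least 3.1-fold lower number from compound 2 to compound 3 (0.50 log units; beyond the scatter).

Compound 4, `COc1ccc(C(=O)CSc2nnc(-c3cc(OC)c(OC)c(OC)c3)n2-c2ccc(N(C)C)cc2)cc1`, has not yet been measured. It differs from compound 3 by methoxy in place of hydrogen on an aromatic carbon. This is the same change as that from compound 1 to compound 2, though cut one bond further out it reads benzoyl to (4-methoxyphenyl)carbonyl rather than phenyl to 4-methoxyphenyl. The earlier instance of this change gave no readable step, so compound 4 is expected to sit near compound 3, with its value taken as 22000 nM in this assay. For compound 4 the expected step is a 1.2-fold higher number from compound 3 to compound 4 (0.07 log units; within the scatter). This rests on the value of compound 3, 18900 nM, and on the unreadable step that the two limits leave unreadable from compound 1 to compound 2. For compound 4 the expected value is estimated to lie between 7000 nM and 60000 nM, a range that allows for a return to the limit.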

Compound 4, half-maximal inhibitory concentration: 18800 nM
Compound 4: the middle estimate sits 1.2-fold (0.07 log units) above what was measured, within the range that was stated.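

In this assay, methoxy in place of hydrogen on an aromatic carbon, para to a large group, gives a 1.0-fold lower number from compound 3 to compound 4 (0.00 log units; within the scatter), so with the benzoyl side chain the values on either side of this change cannot be told apart. The same change from compound 1 to compound 2, on the phenyl side chain, gives no size to set against this one, and the steps of that kind cannot be read, because both of its ends sit at a limit and not at a number: the limit of > 60000 nM in this assay, at which 2 of the 4 values shown sit. Carrying the change from one side chain to the other therefore rests on a single readable instance, which does not show whether methoxy would be equally without consequence where the carbonyl is absent, while the carbonyl-bearing compound stands apart from both limit compounds, with an at least 3.1-fold lower number from compound 2 to compound 4 (0.50 log units; beyond the scatter) and an at least 3.1-fold lower number from compound 1 to compound 4 (0.50 log units; beyond the scatter), each step bounded on one side only.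

The compounds shown leave open whether another group at that place on the ring, such as a chlorine atom, a dimethylamino group or a carboxylic acid, would move the number beyond the scatter. They also leave open what a longer chain on the sulfur, in place of benzoylmethyl, would do in this assay.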